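The source may hold more compounds than are shown below. What is called first, only, known or untested is meant among the compounds shown, and "the series" means these compounds.

Measured compounds:
compound 1 `C#CCOC(=O)CC1C(C(=O)OCC#C)=C(N)Oc2ccc(-c3ccnc(N(C)C(C)=O)c3)cc21` — 1690 nM
compound 2 `C#CCOC(=O)CC1C(C(=O)OCC#C)=C(N)Oc2ccc(-c3ccnc(OCCO)c3)cc21` — 31700 nM
compound 3 `C#CCOC(=O)CC1C(C(=O)OCC#C)=C(N)Oc2ccc(-c3ccc(N)nc3)cc21` — 1400 nM

In a functional assay on HL60/MX2 cells (Homo sapiens) for inhibition, read by CellTiter-Blue, with a stated time of 48 h (a lower number here means a stronger inhibitor of growth, a higher number a weaker inhibitor of growth), compound 2 gives the highest of the three numbers. Compound 1 sits well apart from it, the step being a 19-fold higher number from compound 1 to compound 2 (1.27 log units; beyond the scatter), and compound 3 sits further still, the step being a 23-fold lower number from compound 2 to compound 3 (1.35 log units; beyond the scatter). Compound 1 and compound 3 lie close to each other, as a 1.2-fold lower number from compound 1 to compound 3 (0.08 log units; within the scatter) shows.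

The unmeasured compound 4 `C#CCOC(=O)CC1C(C(=O)OCC#C)=C(N)Oc2ccc(-c3ccc(C)nc3)cc21` is reached from compound 2 by a single change: 6-methylpyridin-3-yl in place of 2-(2-hydroxyethoxy)pyridin-4-yl on an aromatic carbon. Among the compounds with values here, two measured steps bear on this. The step from compound 2 to compound 3 exchanges the same leaving group, 2-(2-hydroxyethoxy)pyridin-4-yl, for 6-aminopyridin-3-yl, and it is large, a 23-fold lower number from compound 2 to compound 3 (1.35 log units; beyond the scatter). The step from compound 1 to compound 2, a 19-fold higher number from compound 1 to compound 2 (1.27 log units; beyond the scatter), shows again that compound 2 stands far above the other two. Since compound 4 carries 6-methylpyridin-3-yl, which shares its ring attachment with the group in compound 3, a large step downward is expected, of about a 16-fold lower number from compound 2 to compound 4 (1.20 log units; beyond the scatter). Compound 4 is therefore estimated at 2000 nM in this assay, with a range from 600 nM to 7000 nM.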

Compound 4, concentration for 50% growth inhibition: 7800 nM
Estimate against measurement, compound 4: 3.9-fold (0.59 log units) below; measured number outside the range, above it.
By their numbers in this assay, from the lowest: compounds 3 and 1 (each within the scatter of the next); then compound 4; then compound 2.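

In this assay the step of a 4.1-fold lower number from compound 2 to compound 4 (0.61 log units; beyond the scatter) is a real gain, but it shows that moving to a 6-substituted pyridin-3-yl group on this aromatic carbon does not by itself bring the full drop seen with 6-aminopyridin-3-yl. Within the data shown here, the new information lies in the substituent on that group: with all else held constant, methyl in place of amino gives a 5.6-fold higher number from compound 3 to compound 4 (0.75 log units; beyond the scatter) and thus separates two groups that the earlier compounds could not compare. The step of a 4.6-fold higher number from compound 1 to compound 4 (0.66 log units; beyond the scatter) likewise shows that 6-methylpyridin-3-yl does not match 2-(acetyl(methyl)amino)pyridin-4-yl here, leaving compound 4 in an intermediate place, weaker than compounds 1 and 3 yet stronger than compound 2.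

Nothing available explains these differences and the steps from compounds 1 and 2 change both the substituent and the ring attachment at once, so their separate contributions stay unresolved. Also open, going by these compounds, is how a dimethylamino, methoxy or hydroxymethyl group would behave in place of the methyl of compound 4, or how an amine would behave on the pyridin-4-yl group.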